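The source may report more compounds than this note shows. Statements on the series, on what has been measured and on what is new or still open speak of the compounds shown alone.

Measured in a physicochemical assay for solubility, read by HPLC; on this read-out lower numbers stand for lower solubility and higher numbers for higher solubility:
compound 1, `CSCC(=O)N1CCN(c2nc(=O)c3cc(C(F)(F)F)cc([N+](=O)[O-])c3s2)CC1`: 15.2 ug/mL
compound 2, `O=C(C1CC1)N1CCN(c2nc(=O)c3cc(C(F)(F)F)cc([N+](=O)[O-])c3s2)CC1`: 52.9 ug/mL
compound 3, `CCC(C)C(=O)N1CCN(c2nc(=O)c3cc(C(F)(F)F)cc([N+](=O)[O-])c3s2)CC1`: 104 ug/mL

Compound 1 stands lowest of the three. Its nearest neighbour is compound 2, a 3.5-fold higher number from compound 1 to compound 2 (0.54 log units; beyond the scatter); its furthest is compound 3, a 6.8-fold higher number from compound 1 to compound 3 (0.84 log units; beyond the scatter). Between those two, a 2.0-fold higher number from compound 2 to compound 3 (0.29 log units; within the scatter), so the hydrocarbon replacements are not separated from each other.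

Compound 4, `O=C(C1CCCCC1)N1CCN(c2nc(=O)c3cc(C(F)(F)F)cc([N+](=O)[O-])c3s2)CC1`, is obtained from compound 1 by a change at the same carbonyl carbon: cyclohexyl in place of (methylsulfanyl)methyl on a carbonyl carbon

Both measured steps from compound 1 bear on this one, each swapping the (methylsulfanyl)methyl group for a hydrocarbon and each giving a modest rise in this assay. For the measured compounds named here, a rise of similar size is therefore expected, a 3.0-fold higher number from compound 1 to compound 4 (0.47 log units; beyond the scatter), though the larger ring has no close precedent here. Compound 4 is estimated at 45 ug/mL, within 12 ug/mL to 140 ug/mL.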

Compound 4, solubility: 3.24 ug/mL
Estimate against measurement, compound 4: 14-fold (1.14 log units) above; the measured number lies below the stated range.
By their numbers in this assay, from the lowest: compound 4; then compound 1; then compounds 2 and 3 (each within the scatter of the next).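

In this assay, the change at this carbonyl carbon has no single direction among hydrocarbon groups: cyclohexyl gives the opposite outcome to cyclopropyl and sec-butyl (a 4.7-fold lower number from compound 1 to compound 4 (0.67 log units; beyond the scatter)). The gaps to the two smaller groups are larger still (a 16-fold lower number from compound 2 to compound 4 (1.21 log units; beyond the scatter); a 32-fold lower number from compound 3 to compound 4 (1.51 log units; beyond the scatter)). Replacing (methylsulfanyl)methyl with a hydrocarbon therefore cannot be read as a general gain at this position. No measurement shown accounts for the reversal.

Open, on these data alone, is where an amine, a carboxylic acid or a longer chain on this carbonyl carbon would fall relative to compound 4 and compound 3.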